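The source may hold more compounds than are shown below. What is called first, only, known or untested is meant among the compounds shown, and "the series" means these compounds.

Measured in a functional assay on A549 cells (Homo sapiens) for inhibition, read by CCK-8 assay, with a stated time of 48 h; on this read-out lower numbers stand for stronger inhibition and higher numbers for weaker inhibition:

- compound 1, `COc1cc(-c2ccnc3cc(-c4ccc5cc[nH]c5c4)nn23)cc(OC)c1OC`, gives 170 nM
- compound 2, `COc1cc(-c2ccnc3cc(-c4ccc5ccn(C)c5c4)nn23)cc(OC)c1OC`, gives 829 nM
- compound 3, `COc1cc(-c2ccnc3cc(-c4ccc(N(C)C)cc4)nn23)cc(OC)c1OC`, gives 1100 nM

Compound 3 holds the highest number of the three. Its nearest neighbour is compound 2, with a 1.3-fold higher number from compound 2 to compound 3 (0.12 log units; within the scatter), while compound 1 is furthest, with a 6.5-fold higher number from compound 1 to compound 3 (0.81 log units; beyond the scatter).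

Compound 4, `COc1cc(-c2ccnc3cc(-c4cn(C)c5ccccc45)nn23)cc(OC)c1OC`, differs from compound 3 in one place: 1-methyl-1H-indol-3-yl in place of 4-(dimethylamino)phenyl on an aromatic carbon.

For the measured compounds named here, two measured steps bear on this change. The step of a 1.3-fold higher number from compound 2 to compound 3 (0.12 log units; within the scatter) shows that exchanging a methylated indole for the 4-(dimethylamino)phenyl group hardly moved the number, and the step of a 4.9-fold higher number from compound 1 to compound 2 (0.69 log units; beyond the scatter) shows that methylating the indole nitrogen costs a modest amount. Going by the values given here, compound 4 carries a methylated indole again, though attached through a different ring carbon than in compound 2, for which no measured pair exists. On this basis a small shift toward a lower number is expected for compound 4, within the scatter, amounting to a 1.4-fold lower number from compound 3 to compound 4 (0.14 log units; within the scatter).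

Compound 4 is therefore estimated at 800 nM, with a range from 250 nM to 3000 nM.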

Compound 4, half-maximal inhibitory concentration: 1340 nM
The estimate for compound 4 lay 1.7-fold (0.22 log units) below the measured number; low and high end bracket the measured number.
By their numbers in this assay, from the lowest: compound 1; then compounds 2, 3 and 4 (each within the scatter of the next).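

In this assay, moving the attachment point of the methylated indole, with 1-methyl-1H-indol-3-yl in place of 1-methyl-1H-indol-6-yl, gave a 1.6-fold higher number from compound 2 to compound 4 (0.21 log units; within the scatter), so this change left no mark beyond the scatter. The exchange for the 4-(dimethylamino)phenyl group gave a 1.2-fold higher number from compound 3 to compound 4 (0.09 log units; within the scatter), so the three groups carried on this aromatic carbon without a hydrogen on nitrogen cannot be told apart on this read-out. The 1H-indol-6-yl group alone stays separate, with a 7.9-fold higher number from compound 1 to compound 4 (0.90 log units; beyond the scatter), although that step changes the attachment point and the methyl together.

No evidence is at hand to explain these numbers. Going by these compounds, it remains open how a 1H-indol-3-yl group, keeping the hydrogen on the indole nitrogen, would compare with the 1H-indol-6-yl group, and how an amine or a carboxylic acid on the indole would fare.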